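Adding a ring methyl to compound 2

A few compounds are considered here, and "the series" means these few. Any claim that something is new, unique, unknown or untested is made for them only; others in the source may bear on it.

Values in a functional assay on the whole organism with Mus musculus as the target, in the maximal electroshock model; a lower number here means that less compound is needed, a higher number that more compound is needed for the effect:
- Compound 1 `CCC1CCSC1=O`: 232 mg/kg
- Compound 2 `CC(C)C1CCSC1=O`: > 500 mg/kg (a limit)
- Compound 3 `CC(C)(C)C1CCSC1=O`: > 500 mg/kg (a limit)
- Compound 4 `CC(C)C1(C)CCSC1=O`: not yet measured

From the compounds shown here alone, compound 2 stands at the limit of > 500 mg/kg in this assay, at which 2 of the 3 values shown sit, so its true value is unknown. Compound 4 carries a methyl in place of hydrogen on a saturated ring carbon. Two measured steps added a methyl on the chain instead: an at least 2.1-fold higher number from compound 1 to compound 2 (0.33 log units; beyond the scatter) and a step that the two limits leave unreadable from compound 2 to compound 3. Neither tests this ring carbon, so both are only loose guides. Compound 1 gives 232 mg/kg, which shows that the shared core can reach a readable number. A modest move toward a lower number is therefore expected, with much uncertainty, as an at least 1.4-fold lower number from compound 2 to compound 4 (0.15 log units; that floor lies within the scatter). For compound 4 the estimated value is 350 mg/kg, with an expected range of 130 mg/kg to 800 mg/kg.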

Compound 4, dose for half-maximal effect: > 500 mg/kg
Compound 4 ended at the assay's limit; the forecaster's own chance of this, stated with the estimate: 40%; middle value at least 1.4-fold (0.15 log units) from the limit.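

Going by these compounds alone, compound 2 and compound 4 both end at a limit rather than a number, so no step between them can be read: the limit of > 500 mg/kg in this assay, at which 3 of the 4 values shown sit.

From the compounds shown here alone, whether the methyl on the saturated ring carbon changes the true dose, in either direction or by any amount, stays open.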